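Ring swap on the aryl amine of compound 1

This account rests on a few compounds, and the source may have more. Where it says the series, first, only, none or still open, it means among the compounds named here.

Compound 1 `C[C@@H]1CN(c2cccc3c2C[C@H](CN(C)[C@H]2CCCc4cccnc42)NC3)C[C@H](C)N1` gives 61 nM in a functional assay on CCRF-CEM cells for antagonist activity at C-X-C chemokine receptor type 4 (Homo sapiens), read by calcium flux, with stated times of 25 min and 90 s (on this read-out lower numbers stand for stronger inhibition and higher numbers for weaker inhibition), the second highest of the three numbers recorded so far. Compound 2 `Cc1cnc(CN(C)C[C@H]2Cc3c(cccc3N3CCNCC3)CN2)c(C)c1` gives 21.4 nM in this assay, a lower number beyond the scatter, and compound 3 `FC1(F)CCC(CN(C[C@H]2Cc3c(cccc3N3CCNCC3)CN2)[C@H]2CCCc3cccnc32)CC1` gives 498 nM, the highest of the set. Compound 4 `CN(C[C@H]1Cc2c(cccc2N2C[C@@H]3C[C@H]2CN3)CN1)[C@H]1CCCc2cccnc21` has not been measured in this assay. It differs from compound 1 in one place: a group of 7 heavy atoms (5 carbon, 2 nitrogen; 2 five-membered non-aromatic rings with 1 hetero atom each) in place of a group of 8 heavy atoms (6 carbon, 2 nitrogen; one six-membered non-aromatic ring with 2 hetero atoms), on an aromatic carbon. The group enters on an aromatic carbon of the six-membered carbon-only aromatic ring of the shared core, ortho to a fused ring and meta to a fused ring. For the measured compounds named here, no measured pair shows this change, so no step size can be read from the data; the expectation is a step of a 1.2-fold lower number from compound 1 to compound 4 (0.09 log units; within the scatter), not beyond the scatter in either direction. Compound 4 is therefore estimated at 50 nM, within 15 nM to 200 nM.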

Compound 4, half-maximal inhibitory concentration: 146 nM
Compound 4: the middle estimate sits 2.9-fold (0.47 log units) below what was measured; measured number inside the range.
By their numbers in this assay, from the lowest: compound 2; then compound 1; then compound 4; then compound 3.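

On the aromatic carbon of the shared core, this position does not accept the ring change without cost: in this assay, replacing 3,5-dimethylpiperazin-1-yl with the group of two five-membered non-aromatic rings gives a 2.4-fold higher number from compound 1 to compound 4 (0.38 log units; beyond the scatter), a modest step. The two groups have the same hydrogen-bond donor and acceptor counts, so the step arises with those counts unchanged. Nothing available explains the step.

Still open, as far as these compounds go, is how a morpholine ring at this position would read. From the compounds shown here alone, it is also open whether the same step would appear with the side chains of compound 2 or compound 3.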